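From an amide to a carbamate on the nitrogen

The compounds below may be only part of what the source reports. "The series", "measured", "known", "first", "only" and "open" are said of these compounds alone.

Values so far in a functional assay on the whole organism with Mus musculus as the target; a lower number here means that less compound is needed, a higher number that more compound is needed for the effect:
Compound 1 `Cc1c(C)c2c(c(C)c1N)CC(C)(C)O2` gives 7.8 mg/kg
Compound 2 `CC(=O)Nc1c(C)c(C)c2c(c1C)CC(C)(C)O2` gives > 100 mg/kg (a limit)
Compound 3 `CCC(=O)Nc1c(C)c(C)c2c(c1C)CC(C)(C)O2` gives > 100 mg/kg (a limit)

Compound 3 stands at the limit of > 100 mg/kg in this assay, at which 2 of the 3 values shown sit, so it has only a limit and no number. Compound 4 `CCOC(=O)Nc1c(C)c(C)c2c(c1C)CC(C)(C)O2` carries ethoxy in place of ethyl on a carbonyl carbon, which turns propanoyl into ethoxycarbonyl. Two measured steps put such a carbonyl group on the nitrogen: an at least 12-fold higher number from compound 1 to compound 2 (1.10 log units; beyond the scatter) and an at least 12-fold higher number from compound 1 to compound 3 (1.10 log units; beyond the scatter), both large and beyond the scatter. The third, a step that the two limits leave unreadable from compound 2 to compound 3, gives no size. Compound 4 keeps the carbonyl on that nitrogen, so the high side reached in an at least 12-fold higher number from compound 1 to compound 3 (1.10 log units; beyond the scatter) is expected to hold, with no clear move in this assay. The expected change is a step that the limit leaves unreadable from compound 3 to compound 4. For compound 4 the estimate is 120 mg/kg, with an expected range of 40 mg/kg to 350 mg/kg.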

Compound 4, dose for 50% inhibition: > 100 mg/kg
Compound 4 ended at the assay's limit; the forecaster's own chance of this, stated with the estimate: 75%; the middle value lies beyond the limit too.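

A carbamate now joins the two amides: in this assay, ethoxycarbonyl in place of hydrogen on the nitrogen gives an at least 12-fold higher number from compound 1 to compound 4 (1.10 log units; beyond the scatter), so the loss seen with acetyl and propanoyl also appears with ethoxy on the carbonyl. Compound 4 has only a limit, > 100 mg/kg, and the steps among compounds 2, 3 and 4 cannot be read, so these three cannot be ranked. All three carbonyl compounds sit at one shared limit: the limit of > 100 mg/kg in this assay, at which 3 of the 4 values shown sit.

Going by these compounds, whether a group on this nitrogen without a carbonyl, such as methyl or methanesulfonyl, would keep the effect of compound 1 remains open. So does how far beyond the limit compounds 2, 3 and 4 truly lie.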